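From methoxy to nitro in a growth inhibition series

This account rests on a few compounds, and the source may have more. Where it says the series, first, only, none or still open, it means among the compounds named here.

- compound 1 `N#C/C(=C\c1ccccc1OS(=O)(=O)c1ccc([N+](=O)[O-])cc1)C(=O)Nc1nnc(Cc2cccc(F)c2)s1` gives 65% as its measured value
- compound 2 `COc1ccc(S(=O)(=O)Oc2ccccc2/C=C(\C#N)C(=O)Nc2nnc(Cc3ccc(C)cc3)s2)cc1` gives 79% as its measured value

In a functional assay on RS4-11 cells (Homo sapiens) for inhibition, read by CCK-8 assay, with a stated time of 48 h, tested at 20 uM (on this read-out higher numbers stand for more inhibition of growth at the one concentration tested and lower numbers for less inhibition of growth), compound 2 gives 79% and stands highest of the two, beyond the scatter above compound 1. Compound 3 `Cc1ccc(Cc2nnc(NC(=O)/C(C#N)=C/c3ccccc3OS(=O)(=O)c3ccc([N+](=O)[O-])cc3)s2)cc1` departs from compound 2 by nitro in place of methoxy on an aromatic carbon with nitro in place of methoxy on an aromatic carbon. Among the measured compounds shown here, compound 1, which also bears 4-nitrophenyl but differs elsewhere too, gives 65% in this assay and is the only guide. The expected step is a small fall, estimated as a number 9 percentage points lower from compound 2 to compound 3 (within the scatter) and thus within the scatter. The expected value for compound 3 is 70% with an estimated range from 55% to 84% on this read-out.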

Compound 3, percent growth inhibition at one concentration: 64%
Compound 3: middle estimate off by 6 percentage points, on the high side; measured number inside the range.
By their numbers in this assay, from the lowest: compounds 3 and 1 (each within the scatter of the next); then compound 2.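

In this assay, nitro in place of methoxy on this aromatic carbon, para to a large group, gives a number 15 percentage points lower from compound 2 to compound 3 (beyond the scatter), so this position responds to the change when nothing else differs. 4-Methylphenyl in place of 3-fluorophenyl gives a number 1 percentage points lower from compound 1 to compound 3 (within the scatter), so that exchange shows no separable effect with nitro present. No measured evidence bears on this fall. From the compounds shown here alone, it remains open whether an amine on this carbon would read closer to methoxy or to nitro, and whether the methoxy-to-nitro step holds alongside 3-fluorophenyl.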